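Methoxy on the aromatic ring: expecting compound 4

The source may report more compounds than this note shows. Statements on the series, on what has been measured and on what is new or still open speak of the compounds shown alone.

Three compounds have been tested in a toxicity assay on MCF-10A cells (Homo sapiens) for cytotoxicity, read by MTT assay, with a stated time of 48 h; on this read-out higher numbers stand for weaker inhibition and lower numbers for stronger inhibition:

Compound 1, `O=C(/C=C/c1ccc2c(c1)B(O)OC2)c1ccccc1`, gives 15900 nM.
Compound 2, `Cn1cccc1C(=O)/C=C/c1ccc2c(c1)B(O)OC2`, gives only a limit, > 100000 nM.
Compound 3, `O=C(/C=C/c1ccc2c(c1)B(O)OC2)c1ccc(Cl)cc1`, gives 12100 nM.

Compound 1 and compound 3 sit within the usual scatter of each other, as the step of a 1.3-fold lower number from compound 1 to compound 3 (0.12 log units; within the scatter) shows. For compound 2 the assay reports a limit rather than a number (the limit of > 100000 nM in this assay, at which 1 of the 3 values shown sits). Compound 4, `COc1cccc(C(=O)/C=C/c2ccc3c(c2)B(O)OC3)c1`, has not yet been measured. It differs from compound 1 in one place: methoxy in place of hydrogen on an aromatic carbon. The two measured steps from compound 1 are of different kinds. Swapping the whole phenyl for 1-methyl-1H-pyrrol-2-yl gave an at least 6.2-fold higher number from compound 1 to compound 2 (0.79 log units; beyond the scatter), a shift beyond the scatter. Adding a single chloro to the phenyl gave a 1.3-fold lower number from compound 1 to compound 3 (0.12 log units; within the scatter), no change beyond the scatter. The change to compound 4 is of the second kind, a single group placed on the same aromatic ring, so no step beyond the scatter is expected in this assay. The expected step is a 1.1-fold lower number from compound 1 to compound 4 (0.06 log units; within the scatter). Compound 4 is therefore estimated at 14000 nM, with a range from 6000 nM to 40000 nM.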

Compound 4, half-maximal inhibitory concentration: 7400 nM
For compound 4 the middle estimate is 1.9-fold (0.28 log units) above the measured one; the range from low to high includes it.
By their numbers in this assay, from the lowest: compounds 4, 3 and 1 (each within the scatter of the next, the first and the last beyond it). At a limit, above all of these: compound 2.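

Among these compounds, with methoxy in place of hydrogen on an aromatic carbon, meta to a large group, this assay gives a 2.1-fold lower number from compound 1 to compound 4 (0.33 log units; beyond the scatter) and thus the first change on this phenyl ring to move the number beyond the scatter, although only modestly. Chloro on the same ring gave a 1.3-fold lower number from compound 1 to compound 3 (0.12 log units; within the scatter) and so did not show that a single small group on the ring can shift the result; compound 4 shows that such a change need not be silent, and the direction here is towards stronger inhibition of these cells. Nothing among the measurements shown gives a reason for this step.

Among the compounds shown here, it remains open whether the shift belongs to methoxy itself or to its place on the ring, since methoxy appears at only this one place and chloro is the only other group on the phenyl ring. A hydroxyl, an amine, a carboxylic acid or a longer chain such as ethoxy at the same place would show how much this position tolerates and whether the modest shift can grow.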